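Moving the methoxy group on a sulfamoyl compound

The source may hold more compounds than are shown below. What is called first, only, known or untested is meant among the compounds shown, and "the series" means these compounds.

compound 1 `COc1ccc(-c2ccnc(Nc3cccc(S(N)(=O)=O)c3)n2)cc1` 2.7
compound 2 `COc1ccc(-c2ccnc(Nc3cccc(C(N)=O)c3)n2)cc1` 3.1
compound 3 `COc1ccc(-c2ccnc(Nc3cccc(NS(C)(=O)=O)c3)n2)cc1` 3.2

In a physicochemical assay for lipophilicity, read by HPLC, using the shake flask method, in phosphate buffer, measured as octanol-water partition, with a stated time of 6 h, at pH 7.4 (on this read-out higher numbers stand for higher lipophilicity and lower numbers for lower lipophilicity), compound 1 stands at 2.7, the lowest of the three numbers and beyond the scatter from both others. Compound 4 `COc1cccc(-c2ccnc(Nc3cccc(S(N)(=O)=O)c3)n2)c1` has the same atoms joined differently, with 3-methoxyphenyl in place of 4-methoxyphenyl on an aromatic carbon in the core of compound 1. The measured steps all concern another group: a number 0.40 log units higher from compound 1 to compound 2 (beyond the scatter) and a number 0.50 log units higher from compound 1 to compound 3 (beyond the scatter), whereas a number 0.10 log units higher from compound 2 to compound 3 (within the scatter) stays within the scatter. None of them measures this change, and compound 1 alone carries the same sulfamoyl group. The expected outcome is therefore no step beyond the scatter, an estimated a number 0.10 log units higher from compound 1 to compound 4 (within the scatter) in size. In this assay the expected value of compound 4 is 2.8, with an estimated range from 2.4 to 3.2.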

Compound 4, distribution coefficient: 3
Compound 4: middle estimate off by 0.20 log units, on the low side; low and high end bracket the measured number.
By their numbers in this assay, from the lowest: compounds 1, 4, 2 and 3 (each within the scatter of the next, the first and the last beyond it).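

In this assay, among the compounds shown here, the first reading at this position gives a number 0.30 log units higher from compound 1 to compound 4 (within the scatter) for 3-methoxyphenyl in place of 4-methoxyphenyl, so this change of the methoxy group's place on the ring stays within the scatter. The earlier steps shown here concerned only the sulfamoyl group and its replacements, and the sulfamoyl compound now has a measured partner that differs in the core alone. Nothing shown accounts for this result. As far as these compounds go, it remains open whether a carboxylic acid or an amine in place of the methoxy group would also stay within the scatter, and whether the same move on compound 2 would give a similar step.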